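The compounds below may be only part of what the source reports. "The series", "measured", "known", "first", "only" and "open" are said of these compounds alone.

In a functional assay on SK-BR-3 cells (Homo sapiens) for antiproliferative activity, read by MTT assay, with a stated time of 72 h (on this read-out higher numbers stand for weaker inhibition and lower numbers for stronger inhibition), compound 1 `C/C=C1/[C@H](O[C@@H]2O[C@H](CO)[C@@H](O)[C@H](O)[C@H]2O)OC=C(C(=O)OC)[C@H]1CC(=O)NCCC` gives > 20000 nM, which is a limit of the assay and not a number. Compound 3 `C/C=C1/[C@H](O[C@@H]2O[C@H](COC(C)=O)[C@@H](OC(C)=O)[C@H](OC(C)=O)[C@H]2OC(C)=O)OC=C(C(=O)OC)[C@H]1CC(=O)SCCC` gives > 15000 nM, which is also a limit. Going by the values given here, compound 2 `C/C=C1/[C@H](O[C@@H]2O[C@H](CO)[C@@H](O)[C@H](O)[C@H]2O)OC=C(C(=O)OC)[C@H]1CC(=O)OCCCCCCCCCCCCCCC`, which has an ester oxygen on the same carbonyl carbon, gives 1600 nM, the only value of the three that is not a limit. Compound 4 `C=C(C)CCOC(=O)C[C@@H]1C(C(=O)OC)=CO[C@@H](O[C@@H]2O[C@H](CO)[C@@H](O)[C@H](O)[C@H]2O)/C1=C/C` departs from compound 1 in one place: (3-methylbut-3-en-1-yl)oxy in place of propylamino on a carbonyl carbon. It has (3-methylbut-3-en-1-yl)oxy in place of propylamino on a carbonyl carbon. Like compound 2 at 1600 nM, it therefore has an oxygen on that carbonyl carbon, but its chain is far shorter. Among the compounds with values here, no measured pair isolates this change, so only a modest move toward stronger inhibition is expected, an at least 1.3-fold lower number from compound 1 to compound 4 (0.12 log units; that floor lies within the scatter), and that expected step may not exceed the usual scatter. For compound 4 the estimated value is 15000 nM, with an expected range of 5000 nM to 40000 nM.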

Compound 4, half-maximal inhibitory concentration: > 15000 nM
Compound 4: only a limit was reported; the forecaster's own chance of this, stated with the estimate: 50%; the middle value sits exactly at the limit.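

Going by these compounds alone, compound 1 and compound 4 are both reported only as limits of the assay and not as numbers, and no step between them can be read. The compounds shown leave open whether (3-methylbut-3-en-1-yl)oxy in place of propylamino on a carbonyl carbon changes inhibition at all.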